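The source may report more compounds than this note shows. Statements on the series, on what has been measured and on what is new or still open speak of the compounds shown alone.

Values so far in a toxicity assay on C8166 cells (Homo sapiens) for cytotoxicity, read by MTT assay, with a stated time of 72 h; a higher number here means that more compound is tolerated, a lower number that less compound is tolerated:
compound 1 (`C[C@@H](Nc1c(C(=O)NCc2ccc(F)cc2)nc(Br)c2cccnc12)c1ccccc1`) gives "not determined" (no result reported)
compound 2 (`O=C(NCc1ccc(F)cc1)c1nc(Br)c2cccnc2c1NCCO`) gives 232000 nM
compound 3 (`O=C(NCc1ccc(F)cc1)c1nc(Br)c2cccnc2c1NCc1ccccc1`) gives "not determined" (no result reported)

Among the compounds with values here, compound 3 has no single number here, and neither does compound 1, which leaves compound 2 (232000 nM) as the only quantified member of the series. Within the data shown here, no measured step is available either, so the series offers no direct guide to how a structural change moves the read-out.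

The next compound to be measured is compound 4 (`Cc1ccc(S(=O)(=O)Oc2c(C(=O)NCc3ccc(F)cc3)nc(Br)c3cccnc23)cc1`). The change from compound 3 is this: ((4-methylphenyl)sulfonyl)oxy in place of benzylamino on an aromatic carbon. The new ((4-methylphenyl)sulfonyl)oxy group stands on an aromatic carbon of a six-membered aromatic ring with 1 nitrogen, para to a bromo group, where the benzylamino group stood.

With no number for compound 3, the size of this step in this assay cannot be anchored on compound 3 itself. Among the measured compounds shown here, the only anchor is compound 2 (232000 nM). Compound 4 is expected to sit beyond the scatter from that value, on the side of less compound tolerated, although this expectation rests on a single number and remains uncertain. The estimated value for compound 4 is 60000 nM (expected range 15000 nM to 240000 nM).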

Compound 4, half-maximal cytotoxic concentration: 31000 nM
Compound 4: middle estimate off by 1.9-fold (0.29 log units), on the high side, and the stated range covers the measured number.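

In this assay, within the data shown here, exchanging (2-hydroxyethyl)amino for ((4-methylphenyl)sulfonyl)oxy on the aromatic carbon para to a bromo group gives a 7.5-fold lower number from compound 2 to compound 4 (0.87 log units; beyond the scatter), the first readable step. This position is therefore not silent in this read-out: with the rest of the structure unchanged, the group on this carbon alone moves the number beyond the scatter, toward less compound tolerated. The data shown offer no measurement that explains this shift.

From the compounds shown here alone, compound 1 and compound 3 have no single number, so steps involving either of them cannot be read, and the effect of benzylamino relative to the other two groups stays unknown. Going by these compounds, with one step between two very different groups, it also remains open whether a simple hydroxyl, a methoxy or an unsubstituted amine on this carbon would lie closer to compound 2 or to compound 4, and whether the methyl on the new benzene ring contributes to the step.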